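The source may report more compounds than this note shows. Statements on the series, on what has been measured and on what is new or still open speak of the compounds shown alone.

Compound 1 `C#CCN(C)Cc1cccc(NC(=O)CCC(=O)NO)c1` sits at the limit of a functional assay on PC-3 cells (Homo sapiens) for inhibition, read by MTT assay, with a stated time of 48 h; on this read-out lower numbers stand for stronger inhibition of growth and higher numbers for weaker inhibition of growth; in this assay compound 1 gives > 10000 nM. Compound 2 `C#CCN(C)Cc1cccc(NC(=O)CCCCCC(=O)NO)c1` holds the only number shown; in this assay compound 2 gives 4630 nM. The step of an at least 2.1-fold lower number from compound 1 to compound 2 (0.33 log units; beyond the scatter) rests on a limit (the limit of > 10000 nM in this assay, at which 1 of the 2 values shown sits), so its true size is open. Compound 3 `C#CCN(C)Cc1cccc(NC(=O)CCCCCCCCC(=O)NO)c1` repeats that kind of lengthening one stage further: 3-(hydroxycarbamoyl)propyl in place of hydroxycarbamoyl on a saturated chain carbon, five bonds along the chain from a carbonyl carbon. Among the compounds with values here, only that one step bears on it, and it fixes a floor, not a trend, so no step beyond the scatter is expected. Compound 3 is estimated at 6000 nM, range 2500 nM to 15000 nM. The expected step is a 1.3-fold higher number from compound 2 to compound 3 (0.11 log units; within the scatter).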

Compound 3, concentration for 50% growth inhibition: 1790 nM
Estimate against measurement, compound 3: 3.4-fold (0.53 log units) above; measured number outside the range, below it.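

In this assay, this lengthening now yields a step with two measured ends: a 2.6-fold lower number from compound 2 to compound 3 (0.41 log units; beyond the scatter). The number therefore keeps falling past compound 2, and the chain of compound 3 gives the lowest number shown, with no compound going against that order. The full size of the fall remains unknown because compound 1 is held at a limit: the limit of > 10000 nM in this assay, at which 1 of the 3 values shown sits.

As far as these compounds go, whether a longer chain than that of compound 3 lowers the number further remains open. So does whether a carboxylic acid in place of the hydroxycarbamoyl end retains growth inhibition.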